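The source may hold more compounds than are shown below. What is called first, only, known or untested is meant among the compounds shown, and "the series" means these compounds.

Of the compounds shown here, two from this series have been tested in a functional assay (Cavia porcellus) with sulfonylurea receptors; K-ATP channels (Homo sapiens) as the target; a higher number here means a weaker inhibitor, a lower number a stronger inhibitor. Compound 1, `COc1cccc(S(=O)(=O)c2ccc(NC(=O)C(C)(O)C(F)(F)F)cc2)c1`, gives 16000 nM in this assay. Among the compounds with values here, compound 2, `Cc1ccccc1S(=O)(=O)c1ccc(NC(=O)C(C)(O)C(F)(F)F)cc1`, gives 5100 nM in this assay, the lowest of the two numbers so far. Within the data shown here, the only single-point comparison available is the one between them: putting 2-methylphenyl in place of 3-methoxyphenyl on a sulfonyl sulfur gave a 3.1-fold lower number from compound 1 to compound 2 (0.50 log units; beyond the scatter), a modest shift but one beyond the usual scatter.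

Compound 3, `CC(O)(C(=O)Nc1ccc(S(=O)(=O)c2cccnc2)cc1)C(F)(F)F`, changes the same position once more: pyridin-3-yl in place of 2-methylphenyl on a sulfonyl sulfur. Among the measured compounds shown here, no measured step shows this particular exchange, so the step from compound 1 to compound 2 is the only guide, and it shows only that the group on the sulfonyl sulfur can move the number by a modest amount in either direction. With that in mind, the number for compound 3 is expected to shift by a 1.8-fold higher number from compound 2 to compound 3 (0.25 log units; within the scatter), most likely toward a somewhat higher, weaker value than compound 2. The estimate for compound 3 in this assay is 9000 nM, within a range from 3000 nM to 30000 nM.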

Compound 3, half-maximal inhibitory concentration: 3500 nM
Compound 3: the middle estimate sits 2.6-fold (0.41 log units) above what was measured; measured number inside the range.
By their numbers in this assay, from the lowest: compounds 3 and 2 (each within the scatter of the next); then compound 1.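

Pyridin-3-yl, with a nitrogen in its ring, can take the place of the all-carbon 2-methylphenyl on a sulfonyl sulfur in this assay with a difference that stays inside the noise, as the step of a 1.5-fold lower number from compound 2 to compound 3 (0.16 log units; within the scatter) shows. Set against 3-methoxyphenyl, the same ring gives a 4.6-fold lower number from compound 1 to compound 3 (0.66 log units; beyond the scatter) and so a second group now lies clearly apart from compound 1, which has the highest number of the three and is the weakest inhibitor here, while compound 2 and compound 3 cannot be told apart. Nothing available explains why the groups on the sulfur fall in this order.

Within the data shown here, with only three aromatic rings at this position, it remains open whether the place of the ring nitrogen matters, as pyridin-2-yl or pyridin-4-yl would show, and whether 2-methoxyphenyl would behave more like 2-methylphenyl or like 3-methoxyphenyl. As far as these compounds go, it is also open whether a group without a ring, such as a short alkyl chain, or a ring carrying an amine or a carboxylic acid, would keep the number in this range.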